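A few compounds are considered here, and "the series" means these few. Any claim that something is new, unique, unknown or untested is made for them only; others in the source may bear on it.

Compound 1, `O=C1NC(=O)C(Cc2ccc(Oc3cccc(C(F)(F)F)n3)cc2)S1`, in a functional assay for agonist activity at Free fatty acid receptor 1 (Homo sapiens), read by FLIPR, in the presence of a further agent that is not named here (on this read-out higher numbers stand for an effect only at larger amounts of compound and lower numbers for an effect already at smaller amounts), gives 1640 nM.
Compound 2, `Cc1cc(C(F)(F)F)cc(Oc2ccc(CC3SC(=O)NC3=O)cc2)n1`, in this assay gives 218 nM.

Among the compounds with values here, of the two numbers measured so far, compound 2 has the lower one, and the gap to compound 1 lies beyond the usual scatter. Compound 3, `Cc1cccc(Oc2ccc(CC3SC(=O)NC3=O)cc2)n1`, is not yet measured. It differs from compound 2 in one way: hydrogen in place of trifluoromethyl on an aromatic carbon. Within the data shown here, since no measured pair shows this exact change, the expected effect in this assay is judged with caution; the expectation is a moderate shift toward higher numbers for compound 3, a 4.1-fold higher number from compound 2 to compound 3 (0.62 log units; beyond the scatter). Compound 3 is therefore estimated at 900 nM, within a range from 300 nM to 3000 nM.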

Compound 3, half-maximal effective concentration: 2620 nM
Compound 3: the middle estimate sits 2.9-fold (0.46 log units) below what was measured; measured number inside the range.
By their numbers in this assay, from the lowest: compound 2; then compounds 1 and 3 (each within the scatter of the next).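

Replacing trifluoromethyl with hydrogen at this ring carbon gives a 12-fold higher number from compound 2 to compound 3 (1.08 log units; beyond the scatter) in this assay, so the group here strongly affects the read-out when the methyl group is present. Compared with compound 1, which has trifluoromethyl at the ring carbon where compound 3 has methyl, the change gives a 1.6-fold higher number from compound 1 to compound 3 (0.20 log units; within the scatter) and does not separate the two. Nothing available explains the size of the first step. From the compounds shown here alone, whether a chlorine atom, a nitrile or a methoxy group at this carbon would match compound 2 remains open.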